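From pentyl to 4-bromophenyl on the aromatic nitrogen

This account rests on a few compounds, and the source may have more. Where it says the series, first, only, none or still open, it means among the compounds named here.

In a functional assay on HT-29 cells (Homo sapiens) for antiproliferative activity, read by MTT assay, with a stated time of 72 h (a higher number here means a weaker inhibitor, a lower number a stronger inhibitor), compound 1 `CCCCn1ccnc1-c1cc(OC)c(OC)c(OC)c1` gives > 100000 nM, which is a limit of the assay. Compound 2 `COc1cc(-c2nccn2CC(C)C)cc(OC)c1OC` gives > 100000 nM, which is also a limit. Among the compounds with values here, compound 3 `CCCCCn1ccnc1-c1cc(OC)c(OC)c(OC)c1` gives 60100 nM, the only actual number so far in this assay, and (the limit of > 100000 nM in this assay, at which 2 of the 3 values shown sit).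

The next compound is compound 4 `COc1cc(-c2nccn2-c2ccc(Br)cc2)cc(OC)c1OC`, and the change is 4-bromophenyl in place of pentyl on an aromatic nitrogen. In words, 4-bromophenyl stands in place of pentyl on an aromatic nitrogen.

Within the data shown here, three measured steps bear on this only indirectly, as all of them change a saturated chain. Among the measured compounds shown here, the first is a step that the two limits leave unreadable from compound 1 to compound 2. The other two are an at least 1.6-fold lower number from compound 1 to compound 3 (0.22 log units; that floor lies within the scatter) and an at least 1.6-fold lower number from compound 2 to compound 3 (0.22 log units; that floor lies within the scatter). For the measured compounds named here, no measured step replaces a chain with an aromatic ring, so the size of this change is poorly constrained. The only readable signal is the pair of floors leading to compound 3, which gives a weak lean towards a lower number when the group on the nitrogen grows.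

A moderate move in that direction is therefore expected, with the expected size being a 3.0-fold lower number from compound 3 to compound 4 (0.48 log units; beyond the scatter). For compound 4 the estimated value is 20000 nM, with an expected range from 2500 nM to 90000 nM.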

Compound 4, half-maximal inhibitory concentration: 7700 nM
The estimate for compound 4 lay 2.6-fold (0.41 log units) above the measured number; the range from low to high includes it.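

In this assay, the aromatic nitrogen accepts an aromatic ring in place of a chain, and the swap gives a 7.8-fold lower number from compound 3 to compound 4 (0.89 log units; beyond the scatter). Within the data shown here, this is the first step with two real numbers behind it, and it lies beyond the scatter, whereas the chain steps gave only floors within the scatter. Against the other two chains the same swap reads as an at least 12-fold lower number from compound 2 to compound 4 (1.11 log units; beyond the scatter) and as an at least 12-fold lower number from compound 1 to compound 4 (1.11 log units; beyond the scatter), and these two sizes are floors rather than measured sizes because compounds 1 and 2 carry limits instead of numbers: the limit of > 100000 nM in this assay, at which 2 of the 4 values shown sit.

With all three of its steps beyond the scatter, compound 4 is the strongest of the four compounds shown, so this position responds to more than the length of a chain, at least across butyl, isobutyl, pentyl and 4-bromophenyl. On these data alone, the ring and the bromine enter together, so their separate shares remain open, as a plain phenyl, a 4-chlorophenyl or a benzyl group on the same nitrogen would show, and it also remains open whether a longer chain such as hexyl would close any of the gap to compound 4.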